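Removing the Methoxy Group from Compound 3

A few compounds are considered here, and "the series" means these few. Any claim that something is new, unique, unknown or untested is made for them only; others in the source may bear on it.

In a functional assay on HEK293 cells for agonist activity at Glucose-dependent insulinotropic receptor (Homo sapiens), read by fluorescence and cAMP accumulation, with a stated time of 30 min (on this read-out lower numbers stand for an effect already at smaller amounts and higher numbers for an effect only at larger amounts of compound), compound 1 `Cc1c(Nc2ccc(C#N)cc2Cl)ncnc1OC1C2COCC1CN(C(=O)OC(C)(C)C)C2` gives 7 nM; 20 nM (2 entries), two entries whose spread is shown by the several entries of compound 1 in this assay, 7 nM; 20 nM (2 entries). Compound 2 `Cc1c(Nc2ccc(C#N)cc2Cl)ncnc1OC1C2COCC1CN(C(=O)OC1(C)CC1)C2` gives 4 nM and compound 3 `COc1c(Nc2ccc(C#N)cc2Cl)ncnc1OC1C2COCC1CN(C(=O)OC1(C)CC1)C2` gives 7 nM. The step of a 1.8-fold higher number from compound 2 to compound 3 (0.24 log units; within the scatter) lies within the scatter, so the two single numbers stand level with each other. Compound 4 `CC1(OC(=O)N2CC3COCC(C2)C3Oc2cc(Nc3ccc(C#N)cc3Cl)ncn2)CC1` differs from compound 3 by hydrogen in place of methoxy on an aromatic carbon. For the measured compounds named here, the only measured change at this aromatic carbon, methoxy in place of methyl, stayed within the scatter, and no measured step removes the substituent altogether, so the effect of a bare hydrogen there is untested. Compound 4 is therefore expected to give a step of a 2.1-fold higher number from compound 3 to compound 4 (0.33 log units; beyond the scatter). Compound 4 is estimated at 15 nM, between 4 nM and 60 nM.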

Compound 4, half-maximal effective concentration: 25 nM
Estimate against measurement, compound 4: 1.7-fold (0.22 log units) below; the range from low to high includes it.
By their numbers in this assay, from the lowest: compounds 2 and 3 (each within the scatter of the next); then compound 4.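

At this aromatic carbon the substituent counts once it is removed altogether: hydrogen in place of methoxy gives a 3.6-fold higher number from compound 3 to compound 4 (0.55 log units; beyond the scatter), and hydrogen in place of methyl gives a 6.3-fold higher number from compound 2 to compound 4 (0.80 log units; beyond the scatter). Methyl and methoxy stood level, whereas both steps to hydrogen lie beyond the scatter, so either group gives a lower number here than a bare hydrogen. Nothing measured here gives a reason for this. The compounds shown leave open whether chlorine, an ethyl group or an amine at this carbon would match compound 2 and compound 3.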